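The compounds below may be only part of what the source reports. "The series", "measured", "known", "first", "only" and "open" are said of these compounds alone.

Measured so far in an assay on isolated protein for displacement of a labelled ligand from sodium-dependent dopamine transporter (Homo sapiens), tested at 1000 nM; a lower number here means less inhibition, a higher number more inhibition at the concentration tested (going by the name of the read-out):
compound 1 `O[C@](Cc1ccccc1)(c1ccccc1)[C@@H]1CNCCO1`: 5.5%
compound 2 `COc1ccc(C[C@@](O)(c2ccccc2)[C@@H]2CNCCO2)cc1`: 6.2%

Compound 1 sits at the lowest of the two numbers shown, but the only step measured, a number 0.7 percentage points higher from compound 1 to compound 2 (within the scatter), lies within the scatter, so no order between the two measured compounds can be claimed. Compound 3 `COc1cccc(C[C@@](O)(c2ccccc2)[C@@H]2CNCCO2)c1` has not yet been measured. It differs from compound 1 by methoxy in place of hydrogen on an aromatic carbon. Among the compounds with values here, the single measured step that bears on this change, a methoxy in place of hydrogen on an aromatic carbon, is a number 0.7 percentage points higher from compound 1 to compound 2 (within the scatter), a shift within the scatter. Within the data shown here, compound 3 carries the same group on the same six-membered aromatic ring of carbon only, on the carbon meta to a large group, so that step is the only guide available, and it gives no sign of a move in this assay beyond the scatter in either direction. Compound 3 is therefore expected to show a step of a number 0.5 percentage points higher from compound 1 to compound 3 (within the scatter), that is no change beyond the scatter. The expected value for compound 3 in this assay is 6%, with a range from 0% to 16%.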

Compound 3, a percentage reported as inhibition, at one concentration (the size of the read-out at that concentration, not a potency): 4.3%
Estimate against measurement, compound 3: 1.7 percentage points above, and the stated range covers the measured number.
By their numbers in this assay, from the lowest: compounds 3, 1 and 2 (each within the scatter of the next).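

In this assay, methoxy in place of hydrogen on an aromatic carbon, here meta to a large group, gives a number 1.2 percentage points lower from compound 1 to compound 3 (within the scatter) and so shows no shift beyond the scatter at this position. With the earlier a number 0.7 percentage points higher from compound 1 to compound 2 (within the scatter) alongside it, two compounds now carry a methoxy on this six-membered aromatic ring, and neither step from compound 1 leaves the scatter, so the series gives no order among compounds 1, 2 and 3 and no sign that this change matters at either placement. No measurement among the data bears on why the number stays put at this position.

The compounds shown leave open whether a group other than methoxy on the same carbon, such as chlorine, an amine or a carboxylic acid, would give a step beyond the scatter in this assay from compound 1. They also leave open whether a longer chain in place of the methoxy, such as ethoxy or propoxy, would do so at this position.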